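Swapping the piperidine for a dimethoxyanilino group

The source may report more compounds than this note shows. Statements on the series, on what has been measured and on what is new or still open speak of the compounds shown alone.

Measured so far:
- compound 1, `COc1ccc(NC(=O)Nc2nc(Sc3c[nH]c4ccccc34)cc(N3CCCCC3)n2)cc1`: 7260 nM
- compound 2, `Cc1ccc(C)c(NC(=O)Nc2nc(Sc3c[nH]c4ccccc34)cc(N3CCCCC3)n2)c1`: 5940 nM
- compound 3, `O=C(Nc1ccccc1)Nc1nc(NC2CC2)cc(Sc2c[nH]c3ccccc23)n1`: 7860 nM

All three numbers come from a functional assay on MDA-MB-231 cells (Homo sapiens) for inhibition, with a stated time of 72 h; on this read-out lower numbers stand for stronger inhibition and higher numbers for weaker inhibition. Compound 1 sits among them with every difference inside the usual scatter: compound 2 lies a 1.2-fold lower number from compound 1 to compound 2 (0.09 log units; within the scatter) away, and compound 3 is also within scatter of compound 1. Going by the values given here, the one measured step, from compound 1 to compound 2, changes the aryl group on the urea and leaves the number essentially where it was.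

Compound 4, `COc1ccc(NC(=O)Nc2nc(Nc3cc(OC)cc(OC)c3)cc(Sc3c[nH]c4ccccc34)n2)cc1`, is not yet measured. It differs from compound 1 by the change ((3,5-dimethoxyphenyl)amino in place of piperidin-1-yl on an aromatic carbon). Among the compounds with values here, no measured step alters exactly that position on its own. Compound 3 carries a cyclopropylamino group there instead of the piperidine, but it also carries a different urea aryl, so its number can only be read alongside that of compound 1: the two are within scatter of each other. Taken with the flat step from compound 1 to compound 2, the expectation for this assay is a step of a 1.0-fold lower number from compound 1 to compound 4 (0.02 log units; within the scatter), that is, nothing beyond the scatter. Compound 4 is therefore estimated at 7000 nM, with a range from 2500 nM to 20000 nM.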

Compound 4, half-maximal inhibitory concentration: 9460 nM
The estimate for compound 4 lay 1.4-fold (0.13 log units) below the measured number, and the stated range covers the measured number.
By their numbers in this assay, from the lowest: compounds 2, 1, 3 and 4 (each within the scatter of the next).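

Going by these compounds alone, until now, no step had changed this position with the rest of the molecule held fixed, and the urea aryl group had been the only place tested on its own. With that aryl group kept constant, (3,5-dimethoxyphenyl)amino in place of piperidin-1-yl gives a 1.3-fold higher number from compound 1 to compound 4 (0.11 log units; within the scatter) in this assay. The swap replaces a non-aromatic ring with a larger group that has an aromatic ring and a hydrogen-bond donor absent from the piperidine, yet the printed step stays inside the scatter, and no supporting measurement is available to explain this flat result.

Still open, on these data alone, is whether a different kind of group at this position, such as a morpholine, a piperazine or a longer chain ending in a carboxylic acid, would move the number beyond the scatter. The compounds shown also do not tell whether this same swap would read the same way with an aryl group other than 4-methoxyphenyl on the urea.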